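A few compounds are considered here, and "the series" means these few. Any claim that something is new, unique, unknown or untested is made for them only; others in the source may bear on it.

Three analogues share one core. Compound 1 `COc1cc(-c2ccnc3cc(-c4ccc(F)cc4)nn23)cc(OC)c1OC` gives 5030 nM in a functional assay on HCT-116 cells (Homo sapiens) for inhibition, read by CCK-8 assay, with a stated time of 48 h; a higher number here means a weaker inhibitor, a lower number a stronger inhibitor; compound 2 `COc1cc(-c2ccnc3cc(-c4ccc(Cl)cc4)nn23)cc(OC)c1OC` gives 3340 nM; compound 3 `COc1cc(-c2ccnc3cc(-c4ccc(N(C)C)cc4)nn23)cc(OC)c1OC` gives 2050 nM. Compound 2 therefore holds the second highest of the three numbers, with both neighbours within the scatter: a 1.5-fold lower number from compound 1 to compound 2 (0.18 log units; within the scatter) and a 1.6-fold lower number from compound 2 to compound 3 (0.21 log units; within the scatter). Only the wider step a 2.5-fold lower number from compound 1 to compound 3 (0.39 log units; beyond the scatter) goes beyond it. Compound 4 `C=Cc1ccc(-c2cc3nccc(-c4cc(OC)c(OC)c(OC)c4)n3n2)cc1` differs from compound 2 by vinyl in place of chloro on an aromatic carbon. The two single steps that exchange the same group, a 1.5-fold lower number from compound 1 to compound 2 (0.18 log units; within the scatter) and a 1.6-fold lower number from compound 2 to compound 3 (0.21 log units; within the scatter), both stayed within the scatter, so no step beyond the scatter is expected in this assay. Compound 4 is thus estimated at 3000 nM, within a range of 1500 nM to 6500 nM. For compound 4 this means an expected step of a 1.1-fold lower number from compound 2 to compound 4 (0.05 log units; within the scatter).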

Compound 4, half-maximal inhibitory concentration: 1060 nM
Estimate against measurement, compound 4: 2.8-fold (0.45 log units) above; the measured number lies below the stated range.
By their numbers in this assay, from the lowest: compounds 4, 3, 2 and 1 (each within the scatter of the next, the first and the last beyond it).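

Vinyl in place of chloro at this position, on the six-membered aromatic ring of carbon only, moves the number in this assay beyond the scatter (a 3.2-fold lower number from compound 2 to compound 4 (0.50 log units; beyond the scatter)), which neither earlier step from compound 2 did, and the span among these groups widens (a 4.7-fold lower number from compound 1 to compound 4 (0.68 log units; beyond the scatter)). Vinyl and dimethylamino remain within the scatter (a 1.9-fold lower number from compound 3 to compound 4 (0.29 log units; within the scatter)), so this assay does not order them. No measurement shown here explains why vinyl differs from chloro. Going by these compounds, whether an ethyl group or a carboxylic acid at this position would sit with vinyl or with chloro remains open.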